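Compound 1 to compound 4: one group exchanged

The source may hold more compounds than are shown below. What is called first, only, known or untested is meant among the compounds shown, and "the series" means these compounds.

For the measured compounds named here, in a functional assay on MCF7 cells (Homo sapiens) for inhibition, read by MTT assay, with a stated time of 72 h (on this read-out lower numbers stand for stronger inhibition and higher numbers for weaker inhibition), compound 1 (`COc1cccc(/C=C/C(=O)Nc2cc(OC)c(OC)c(OC)c2)c1`) gives 27000 nM, the highest of the three numbers so far and beyond the scatter from both others. Compound 2 (`C=C(Br)C(=O)Nc1cccc(/C=C/C(=O)Nc2ccc(F)c(F)c2)c1`) gives 2690 nM, and compound 3 (`C=C(Br)C(=O)Nc1cccc(/C=C/C(=O)NCc2ccc(C)cc2)c1`) gives 2200 nM. Both of these carry the ((1-bromoethenyl)carbonyl)amino group, which compound 1 lacks.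

Compound 4 (`C=C(Br)C(=O)Nc1cccc(/C=C/C(=O)Nc2cc(OC)c(OC)c(OC)c2)c1`) is compound 1 with one change: ((1-bromoethenyl)carbonyl)amino in place of methoxy on an aromatic carbon, meta to a large group (((1-bromoethenyl)carbonyl)amino in place of methoxy on an aromatic carbon). Going by the values given here, no measured step isolates this exchange. Among the compounds with values here, the one measured step is a 1.2-fold lower number from compound 2 to compound 3 (0.09 log units; within the scatter), which lies within the scatter and comes with 4-methylbenzyl in place of 3,4-difluorophenyl on an amide-type nitrogen. Going by these compounds, compound 4 differs from compound 2 and compound 3 on that same nitrogen, so it is expected to land close to them, although a single step is thin support and its substituent there is untested alongside the new group. Judged from compound 3 at 2200 nM, the expected change is a 12-fold lower number from compound 1 to compound 4 (1.09 log units; beyond the scatter), towards a lower number in this assay and beyond the scatter. For compound 4 the estimate is 2200 nM, with an expected range of 700 nM to 7000 nM.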

Compound 4, half-maximal inhibitory concentration: 1800 nM
For compound 4 the middle estimate is 1.2-fold (0.09 log units) above the measured one; the measured number falls inside the stated range.
By their numbers in this assay, from the lowest: compounds 4, 3 and 2 (each within the scatter of the next); then compound 1.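

Replacing methoxy with ((1-bromoethenyl)carbonyl)amino on this aromatic carbon, meta to a large group, gives in this assay a 15-fold lower number from compound 1 to compound 4 (1.18 log units; beyond the scatter), with the rest of the molecule unchanged. For the compounds shown here, this is the first direct reading of the exchange, since compound 1 differs from compound 2 and compound 3 in more than one place, and it shows that the change at this position alone is beyond the scatter. Compound 4, compound 3 and compound 2 each lie within the scatter of the next despite their different substituents on the amide-type nitrogen, while no available evidence bears on the cause of the step from methoxy to the new group.

Still open, going by these compounds, is how much of the step depends on the whole new group, since a simple amine, an acetylamino group or the same group without bromine on that aromatic carbon would separate its parts. Also open, on these data alone, is whether the close grouping of numbers holds with an alkyl chain or a carboxylic acid on the amide-type nitrogen.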